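Amino for Nitro on the Shared Core

A few compounds are considered here, and "the series" means these few. Any claim that something is new, unique, unknown or untested is made for them only; others in the source may bear on it.

In a functional assay on MCF7 cells (Homo sapiens) for cytotoxicity, read by MTT assay, with a stated time of 96 h (on this read-out lower numbers stand for stronger inhibition and higher numbers for weaker inhibition), compound 1 `COc1cc(C(=O)c2cn(-c3cccc(N)c3)cc2-c2ccc([N+](=O)[O-])cc2)cc(OC)c1OC` gives 110 nM.
Compound 2 `COc1cc(C(=O)c2cn(-c3cccc(N)c3)cc2-c2cccc(N)c2)cc(OC)c1OC` gives 60 nM in this assay.
Compound 3 `COc1cc(C(=O)c2cn(-c3ccc(C)cc3)cc2-c2ccc([N+](=O)[O-])cc2)cc(OC)c1OC` gives 200 nM in this assay.

Compound 4 `COc1cc(C(=O)c2cn(-c3ccc(C)cc3)cc2-c2cccc(N)c2)cc(OC)c1OC` has not yet been measured. From compound 1 to compound 2 the change is 3-aminophenyl in place of 4-nitrophenyl on an aromatic carbon, and the step that came with it was a 1.8-fold lower number from compound 1 to compound 2 (0.26 log units; within the scatter). The cores of compound 1 and compound 3 differ by 4-methylphenyl in place of 3-aminophenyl on an aromatic nitrogen, with a step of a 1.8-fold higher number from compound 1 to compound 3 (0.26 log units; within the scatter). From compound 3 to compound 4 the change is 3-aminophenyl in place of 4-nitrophenyl on an aromatic carbon; around the place it sits two ring bonds from the ring atom that bears a 4-methylphenyl group rather than a 3-aminophenyl group, so this is the same kind of change, not the same one. Because a 1.8-fold lower number from compound 1 to compound 2 (0.26 log units; within the scatter) stayed within the scatter, a step of similar small size is expected here, a 1.8-fold lower number from compound 3 to compound 4 (0.26 log units; within the scatter). Compound 4 is therefore estimated at 110 nM. For compound 4 the expected range runs from 55 nM to 220 nM.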

Compound 4, half-maximal inhibitory concentration: 53 nM
Estimate against measurement, compound 4: 2.1-fold (0.32 log units) above, and the stated range ends above it.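

In this assay, putting 3-aminophenyl in place of 4-nitrophenyl on the core of compound 3 gives a 3.8-fold lower number from compound 3 to compound 4 (0.58 log units; beyond the scatter), and this step does not differ meaningfully from the same change on the core of compound 1: the same change on two cores in this assay, a 1.8-fold lower number (0.26 log units; within the scatter) from compound 1 to compound 2 and a 3.8-fold lower number (0.58 log units; beyond the scatter) from compound 3 to compound 4, 2.1-fold (0.31 log units) apart, within the scatter of two such steps. Putting 4-methylphenyl in place of 3-aminophenyl on an aromatic nitrogen gives a 1.1-fold lower number from compound 2 to compound 4 (0.05 log units; within the scatter), and this step also agrees with its earlier counterpart: the same change on two cores in this assay, a 1.8-fold higher number (0.26 log units; within the scatter) from compound 1 to compound 3 and a 1.1-fold lower number (0.05 log units; within the scatter) from compound 2 to compound 4, 2.1-fold (0.31 log units) apart, within the scatter of two such steps. Both changes therefore carry over between these cores within the scatter, but this rests on just four compounds in one cell assay and shows neither that they would carry over to other cores nor why the numbers move as they do.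

From the compounds shown here alone, it remains open which feature of the 3-aminophenyl change goes with the lower number of compound 4. A plain phenyl, 4-aminophenyl or 3-nitrophenyl group on the same aromatic carbon would help separate the amine from the nitro group and from where each sits on the ring.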